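The source may report more compounds than this note shows. Statements on the series, on what has been measured and on what is new or still open speak of the compounds shown alone.

Measured so far:
Compound 1 `COC(=O)C1=C(C)NC(c2nccs2)=NC1(C)c1ccc(S(C)(=O)=O)cc1`: 57 mL/min/kg
Compound 2 `COC(=O)C1=C(CN2CC3CC2CO3)NC(c2nccs2)=NC1(C)c1ccc(F)cc1`: 84 mL/min/kg

In an ADME assay on microsomes from liver (Mus musculus) for metabolic stability, read by LC-MS, using NADPH, with stated times of 10 min and 30 min, tested at 1 uM (a higher number here means faster removal of the compound, a lower number slower removal), compound 2 gives 84 mL/min/kg and compound 1 gives 57 mL/min/kg, so the two lie within the scatter of each other. Neither can be set apart from the other on these numbers. Going by the values given here, the two also differ in more than one place, so no measured single-place step is available as a guide.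

Compound 3 `COC(=O)C1=C(CN2CCC(O)CC2)NC(c2nccs2)=NC1(C)c1ccc(F)cc1` shares the core of compound 2 and changes one group: a group of 7 heavy atoms (5 carbon, 1 nitrogen, 1 oxygen; one six-membered non-aromatic ring with 1 hetero atom) in place of a group of 7 heavy atoms (5 carbon, 1 nitrogen, 1 oxygen; 2 five-membered non-aromatic rings with 1 hetero atom each), on a saturated chain carbon bound to a double-bonded ring carbon. The group that enters is 4-hydroxypiperidin-1-yl, on a saturated chain carbon bound to a double-bonded ring carbon.

Among the compounds with values here, with no measured precedent for this exchange, the expectation rests on compound 2 at 84 mL/min/kg as the closest measured structure. No step beyond the scatter is expected in this assay, and the direction is uncertain, with a slight lean towards a lower number. The expected step is a 1.2-fold lower number from compound 2 to compound 3 (0.07 log units; within the scatter). For compound 3 the estimated clearance is 72 mL/min/kg, with an expected range of 42 mL/min/kg to 115 mL/min/kg.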

Compound 3, clearance: 81 mL/min/kg
Compound 3: middle estimate off by 1.1-fold (0.05 log units), on the low side, within the range that was stated.
By their numbers in this assay, from the lowest: compounds 1, 3 and 2 (each within the scatter of the next).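

The series now has its first single-place step in this assay: on a saturated chain carbon bound to a double-bonded ring carbon, putting 4-hydroxypiperidin-1-yl in place of the group with 2 five-membered non-aromatic rings gives a 1.0-fold lower number from compound 2 to compound 3 (0.02 log units; within the scatter). For this one pair, a change from two rings to one six-membered ring, with 1 hydrogen-bond donor against 0 and the same count of heavy atoms, leaves the clearance within the scatter. No accompanying measurement is available to explain this result.

Going by these compounds, compound 2 and compound 3 carry groups of the same atom composition at this place, so it remains open whether a different group there, such as an open-chain dimethylamino group or a carboxylic acid, would give a step beyond the scatter. Compound 1 differs from compound 2 and from compound 3 both at this place, where it has a methyl group, and in its methylsulfonyl group in place of fluorine, so neither change can yet be read on its own.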